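Cyclopropyl for vinyl on the branched sugar carbon

A few compounds are considered here, and "the series" means these few. Any claim that something is new, unique, unknown or untested is made for them only; others in the source may bear on it.

Measured so far:
compound 1 `C=C[C@@]1(O)[C@@H](CO)O[C@@H](n2ccc(=O)[nH]c2=O)[C@@H]1O` — 148000 nM
compound 2 `C#C[C@]1(O)[C@H](O)[C@@H](CO)O[C@H]1n1ccc(N)nc1=O` — > 350000 nM

Among the compounds with values here, in a functional assay on L1210 cells (Mus musculus), read by MTT assay (a lower number here means a stronger inhibitor, a higher number a weaker inhibitor), compound 1 gives 148000 nM, the only number in the set. Compound 2 reaches only a limit of the assay, > 350000 nM, and no number (the limit of > 350000 nM in this assay, at which 1 of the 2 values shown sits). Compound 1 and compound 2 differ in more than one place, so nothing is read from the gap between them beyond what the two values show.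

Compound 3 `O=c1ccn([C@@H]2O[C@H](CO)[C@](O)(C3CC3)[C@H]2O)c(=O)[nH]1` is not yet measured. It differs from compound 1 by cyclopropyl in place of vinyl on a saturated ring carbon. The change sits on a saturated ring carbon of a five-membered non-aromatic ring with one oxygen. Within the data shown here, no pair of measured compounds changes a single group, so no measured step sets the size of this one. Swapping one small carbon group for another at the same place is expected to shift the value little, most likely toward weaker inhibition, and a result that is again only a limit cannot be ruled out. The step is expected to be a 1.4-fold higher number from compound 1 to compound 3 (0.13 log units; within the scatter). Compound 3 is estimated at 200000 nM, with a range from 70000 nM to 500000 nM.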

Compound 3, half-maximal inhibitory concentration: > 350000 nM
Compound 3: only a limit was reported (the forecaster's own chance of this, stated with the estimate: 35%); middle value at least 1.7-fold (0.24 log units) from the limit.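

In this assay, compound 3 gives > 350000 nM, which is a limit of the assay and not a number. Cyclopropyl in place of vinyl on the saturated ring carbon is the only single-place step in the series, and it gives an at least 2.3-fold higher number from compound 1 to compound 3 (0.37 log units; beyond the scatter), so this position does not tolerate every exchange of one small carbon group for another without loss in this read-out. Within the data shown here, only a lower bound on the step can be read, and compound 1 remains the only compound with a measured number, so the full size of the loss stays undefined: the limit of > 350000 nM in this assay, at which 2 of the 3 values shown sit.

This single pair cannot separate the loss of the double bond outside the ring from the entry of the three-membered ring or the extra carbon, as all three change together between compound 1 and compound 3. Going by these compounds, whether ethyl, a longer chain or an amine on the same saturated ring carbon would keep a measurable value, or would match the limit reached by compound 3, remains open.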